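The compounds below may be only part of what the source reports. "The series", "measured", "known", "first", "only" and "open" are said of these compounds alone.

Measured so far:
compound 1 `COc1ccccc1C[C@H]1COC[C@@H]1Cc1ccc(Cl)c(Cl)c1` gives 55000 nM
compound 2 `CCOc1ccccc1C[C@H]1COC[C@@H]1Cc1ccc(Cl)c(Cl)c1` gives 29000 nM
compound 3 `Fc1ccccc1C[C@H]1COC[C@@H]1Cc1ccc(Cl)c(Cl)c1` gives 51000 nM

In a functional assay on HL-60 cells (Homo sapiens) for cytotoxicity, read by WST assay, with a stated time of 48 h (a lower number here means that less compound is needed, a higher number that more compound is needed for the effect), compound 3 gives 51000 nM and stands within the scatter of both other compounds. Compound 4 `Oc1ccc(C[C@H]2COC[C@@H]2Cc2ccc(Cl)c(Cl)c2)cc1` has 4-hydroxyphenyl in place of 2-fluorophenyl on a saturated chain carbon bound to a saturated ring carbon. The measured steps all concern the group on the aromatic ring, and a 1.9-fold lower number from compound 1 to compound 2 (0.28 log units; within the scatter) and a 1.1-fold lower number from compound 1 to compound 3 (0.03 log units; within the scatter) and a 1.8-fold higher number from compound 2 to compound 3 (0.25 log units; within the scatter) each stay within the scatter. Going by the values given here, no measured compound carries a hydroxy group, so these steps guide the expectation only loosely. The expected step is a 1.3-fold lower number from compound 3 to compound 4 (0.11 log units; within the scatter) and nothing beyond the scatter is expected in this assay in either direction. Expected for compound 4 is 40000 nM (estimated range 15000 nM to 90000 nM).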

Compound 4, half-maximal effective concentration: 31000 nM
Beside the measured number, compound 4's estimate is 1.3-fold (0.11 log units) above it; the range from low to high includes it.
By their numbers in this assay, from the lowest: compounds 2, 4, 3 and 1 (each within the scatter of the next).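

Going by these compounds alone, the step of a 1.6-fold lower number from compound 3 to compound 4 (0.22 log units; within the scatter) in this assay stays within the scatter, so this position accepts 4-hydroxyphenyl, the first group with a hydrogen-bond donor, without a change that can be read. All four compounds remain within the scatter of the next in order. Nothing available bears on the reason for this result.

This change alters both the substituent and its place on the ring. 4-fluorophenyl would be needed to separate the two. From the compounds shown here alone, whether an amine or a carboxylic acid at this position would produce a step beyond the scatter remains open.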